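This account rests on a few compounds, and the source may have more. Where it says the series, first, only, none or still open, it means among the compounds named here.

Measured compounds in an assay on isolated protein for inhibition of malate dehydrogenase, mitochondrial (Sus scrofa), with stated times of 45 min and 30 min; on this read-out lower numbers stand for stronger inhibition and higher numbers for weaker inhibition:
compound 1 `O=S(=O)(Nc1ccc(-c2nc3ccccc3o2)cc1)c1ccc(Cl)c(C(F)(F)F)c1`, > 63000 nM
compound 2 `Cc1ccc(S(=O)(=O)Nc2ccc(-c3nc4ccccc4o3)cc2)cc1`, > 63000 nM
compound 3 `O=S(=O)(Nc1ccc(-c2nc3ccccc3o2)cc1)c1ccc(F)c(C(F)(F)F)c1`, > 63000 nM

Compound 2 stands only at a limit in this assay; its value of > 63000 nM is a limit of the assay and not a number. The same holds for compound 1, whose > 63000 nM is a limit. Compound 3 likewise sits at a limit with > 63000 nM. All three values therefore share (the limit of > 63000 nM in this assay, at which 3 of the 3 values shown sit).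

Among the measured compounds shown here, the one measured step between two compounds that differ in a single place, a step that the two limits leave unreadable from compound 1 to compound 3, cannot be read in size, since both ends are limits. For the measured compounds named here, no measured step bears directly on the change from compound 2 to compound 4.

Compound 4 `CS(=O)(=O)Nc1ccc(-c2nc3ccccc3o2)cc1` is to be measured in this assay. It differs from compound 2 as follows: methyl in place of 4-methylphenyl on a sulfonyl sulfur. The measured series gives no readable step for this change, and every value shown is a limit. The expected step from this is a step that the limit leaves unreadable from compound 2 to compound 4, with the most likely outcome again a limit rather than a number. Compound 4 is therefore estimated at 100000 nM, with a range from 30000 nM to 400000 nM.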

Compound 4, half-maximal inhibitory concentration: > 63000 nM
Compound 4: a limit, no number; the forecaster's own chance of this, stated with the estimate: 85%; the middle value is on the limit's open side.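

Compound 2 and compound 4 both sit at a limit in this assay, not at a number, so no size can be read for the step from methyl in place of 4-methylphenyl on the sulfonyl sulfur. The compounds shown leave open whether any change to this series gives a readable number, as every value shares one position: the limit of > 63000 nM in this assay, at which 4 of the 4 values shown sit.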